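The source may hold more compounds than are shown below. What is called first, only, known or untested is meant among the compounds shown, and "the series" means these compounds.

Values so far in an ADME assay on SH-SY5Y cells (Homo sapiens) for cytotoxicity, read by MTT assay, with a stated time of 48 h (on this read-out lower numbers stand for an effect already at smaller amounts and higher numbers for an effect only at larger amounts of compound), for the series:
- compound 1 `O=C(NCCCCCCCn1cc(-c2cccnc2)nn1)c1ccccc1-c1cccnc1` gives 36.5 nM
- compound 2 `O=C(NCCCCCCCn1cc(-c2cccnc2)nn1)c1ccccc1-n1ccnn1` gives 35.4 nM

Among the measured compounds shown here, compound 2 at 35.4 nM has only one neighbour on these numbers, compound 1 at 36.5 nM and the two lie within the scatter of each other. The next change leads to compound 3 `O=C(NCCCCCCCn1cc(-c2cccnc2)nn1)c1ccccc1-c1c[nH]nn1` with 1H-1,2,3-triazol-4-yl in place of 1H-1,2,3-triazol-1-yl on an aromatic carbon as the counted difference from compound 2. In words, this is 1H-1,2,3-triazol-4-yl in place of 1H-1,2,3-triazol-1-yl on an aromatic carbon, ortho to a large group.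

For the measured compounds named here, the only measured step bearing on this is a 1.0-fold lower number from compound 1 to compound 2 (0.01 log units; within the scatter) and it concerns the same carbon, where 1H-1,2,3-triazol-1-yl replaced pyridin-3-yl. With that one swap leaving the number within the scatter, no step beyond the scatter is expected in this assay for this change. Going by the values given here, no measured step tests the point of attachment of the triazole itself, so the range stays wide. The expected move is a 1.1-fold higher number from compound 2 to compound 3 (0.05 log units; within the scatter) and no direction is favoured. For compound 3 the estimated value is 40 nM with an expected range of 15 nM to 120 nM for now.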

Compound 3, half-maximal effective concentration: 86.5 nM
Compound 3: the middle estimate sits 2.2-fold (0.33 log units) below what was measured; measured number inside the range.
By their numbers in this assay, from the lowest: compounds 2 and 1 (each within the scatter of the next); then compound 3.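

At this aromatic carbon, ortho to a large group, the number in this assay depends on how the triazole is attached, not only on which ring is present: with the same atoms joined differently, the step is beyond the scatter (a 2.4-fold higher number from compound 2 to compound 3 (0.39 log units; beyond the scatter)). The earlier swap at this carbon, from pyridin-3-yl to 1H-1,2,3-triazol-1-yl, had stayed within the scatter (a 1.0-fold lower number from compound 1 to compound 2 (0.01 log units; within the scatter)), so it gave no sign that this carbon could register a change. The step from the pyridin-3-yl compound is also beyond the scatter (a 2.4-fold higher number from compound 1 to compound 3 (0.37 log units; beyond the scatter)), which sets 1H-1,2,3-triazol-4-yl apart from both other groups, and no measurement at hand accounts for the shift, so the counted gain of a hydrogen-bond donor remains a description only.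

Going by these compounds, whether the higher number tracks that donor remains open, and a methyl group on the triazole nitrogen of the 1H-1,2,3-triazol-4-yl compound would test this directly. Also open, on these data alone, is how a group of another kind at the same carbon, such as a carboxylic acid or an amine, would read in this assay, and whether the step between the triazole attachments persists with a shorter or longer chain.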